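The source may hold more compounds than are shown below. What is called first, only, known or untested is meant among the compounds shown, and "the series" means these compounds.

Of the compounds shown here, three built on one shared core have been measured in a functional assay on NCI-H522 cells (Homo sapiens) for inhibition, read by sulforhodamine B assay, with a stated time of 48 h, tested at 10 uM; on this read-out higher numbers stand for more inhibition at the one concentration tested (going by the name of the read-out) and lower numbers for less inhibition. Compound 1 `c1ccc(-c2cn3ccnc3c(-c3ccc4ncn(C5CCCCC5)c4c3)n2)cc1` gives 58.1%. Compound 2 `O=Cc1ccc(-c2cn3ccnc3c(-c3ccc4ncn(C5CCCCC5)c4c3)n2)cc1`, which carries a formyl group, gives 25.3%, and compound 3 `COc1ccccc1-c1cn2ccnc2c(-c2ccc3ncn(C4CCCCC4)c3c2)n1` gives 22.2%. Among these three numbers compound 2 stands second highest; the nearest of the other two is that of compound 3 and the furthest that of compound 1, as a number 3.1 percentage points lower from compound 2 to compound 3 (within the scatter) and a number 32.8 percentage points lower from compound 1 to compound 2 (beyond the scatter) show. Adding a formyl or a methoxy group to the plain phenyl thus went with a large fall, seen in a number 32.8 percentage points lower from compound 1 to compound 2 (beyond the scatter) and in a number 35.9 percentage points lower from compound 1 to compound 3 (beyond the scatter).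

Compound 4 `c1csc(-c2cn3ccnc3c(-c3ccc4ncn(C5CCCCC5)c4c3)n2)c1` differs from compound 2 as follows: thiophen-2-yl in place of 4-formylphenyl on an aromatic carbon. Within the data shown here, no measured step swaps the phenyl ring for a five-membered ring, so the measured steps bear on this change only indirectly. They show that the unsubstituted phenyl of compound 1 sits well above the substituted phenyls of compounds 2 and 3, and compound 4 likewise carries no substituent on the ring that enters. A rise is therefore expected, though not necessarily all the way back to the level of compound 1. Compound 4 is expected to give 45%, between 22% and 65%, in this assay. The expected step of a number 19.7 percentage points higher from compound 2 to compound 4 (beyond the scatter) is thus upward and beyond the scatter.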

Compound 4, a percentage reported as inhibition, at one concentration (the size of the read-out at that concentration, not a potency): 13.2%
Estimate against measurement, compound 4: 31.8 percentage points above; measured number outside the range, below it.
By their numbers in this assay, from the lowest: compounds 4, 3 and 2 (each within the scatter of the next, the first and the last beyond it); then compound 1.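

In this assay the ring at this position matters even when it carries no substituent: thiophen-2-yl in place of phenyl goes with a number 44.9 percentage points lower from compound 1 to compound 4 (beyond the scatter), so the high number of compound 1 cannot be put down simply to a bare ring. Against the substituted phenyls the picture is mixed, with a number 12.1 percentage points lower from compound 2 to compound 4 (beyond the scatter) set against the 4-formylphenyl but a number 9 percentage points lower from compound 3 to compound 4 (within the scatter) set against the 2-methoxyphenyl, and so far plain phenyl is the one group of the four that stands well clear of all the others at this aromatic carbon. Nothing at hand explains why a five-membered aromatic ring with a sulfur atom goes with so low a number.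

The compounds shown leave open whether a pyridin-3-yl group, a six-membered ring holding nitrogen, would stay near compound 1 or fall towards compound 4. They also leave open whether an amine or a carboxylic acid on the phenyl would lower the number as the formyl and methoxy groups do, since only those two substituents are seen here.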